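Trifluoromethylphenyl thiosemicarbazide tested for cytotoxicity

The source may report more compounds than this note shows. Statements on the series, on what has been measured and on what is new or still open speak of the compounds shown alone.

Measured compounds:
compound 1, `COc1cc2ncnc(NNC(=S)NC(=O)c3ccccc3F)c2cc1OC`, 8640 nM
compound 2, `O=C(NC(=S)NNc1ncnc2ccccc12)c1ccc(Cl)cc1`, 6680 nM

Two compounds have been run in a functional assay on GLC82 cells (Homo sapiens) for cytotoxicity, read by MTT assay, with a stated time of 72 h; a lower number here means a stronger inhibitor, a higher number a weaker inhibitor. In this assay compound 1 gives 8640 nM and compound 2 gives 6680 nM; these two numbers lie within the scatter of each other, so neither stands apart. Compound 3, `COc1cc2ncnc(NNC(=S)NC(=O)c3ccc(C(F)(F)F)cc3)c2cc1OC`, carries 4-(trifluoromethyl)phenyl in place of 2-fluorophenyl on a carbonyl carbon. Going by the values given here, no measured pair shows this kind of exchange, so the step from compound 1 to compound 3 in this assay is expected to stay within the scatter, in no clear direction, as a 1.2-fold lower number from compound 1 to compound 3 (0.06 log units; within the scatter). Compound 3 is therefore estimated at 7500 nM, with a range from 2500 nM to 22000 nM.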

Compound 3, half-maximal inhibitory concentration: 16500 nM
Compound 3: the middle estimate sits 2.2-fold (0.34 log units) below what was measured; low and high end bracket the measured number.
By their numbers in this assay, from the lowest: compounds 2, 1 and 3 (each within the scatter of the next, the first and the last beyond it).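

In this assay, going by these compounds alone, the exchange of 2-fluorophenyl for 4-(trifluoromethyl)phenyl on a carbonyl carbon gives the first reading of this position with the rest of the structure unchanged: a 1.9-fold higher number from compound 1 to compound 3 (0.28 log units; within the scatter). This step stays within the scatter, so the exchange does not clearly separate the two compounds. No available evidence bears on this result.

The compounds shown leave open whether an amine, a carboxylic acid or a longer chain on this carbonyl carbon would stand beyond the scatter of compound 1. They also leave open how the same exchange would read on the core of compound 2.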